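The compounds below may be only part of what the source reports. "The series", "measured", "known", "first", "only" and "open" are said of these compounds alone.

Working notes on the series. Compound 1 `COc1ccc(N2C(=O)C(C)(C)c3cccnc32)cc1` gives 63% in a functional assay on the whole organism (Pleural cavity) for inhibition, with Rattus norvegicus as the target, at a dose of 25 mg/kg; a lower number here means less inhibition, a higher number more inhibition at the dose given (going by the name of the read-out). Compound 2 `C[S+]([O-])c1ccc(N2C(=O)C(C)(C)c3cccnc32)cc1` gives 39% in this assay, and compound 3 `CC1(C)C(=O)N(c2ccc(Br)cc2)c2ncccc21` gives 46% in this assay. Of the three numbers compound 3 stands second highest: its nearest neighbour is compound 2, with a number 7 percentage points higher from compound 2 to compound 3 (within the scatter), and its furthest is compound 1, with a number 17 percentage points lower from compound 1 to compound 3 (beyond the scatter). The remaining measured step is a number 24 percentage points lower from compound 1 to compound 2 (beyond the scatter).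

Compound 4 `CC(C)c1ccc(N2C(=O)C(C)(C)c3cccnc32)cc1` is the next member. The change from compound 3 is isopropyl in place of bromo on an aromatic carbon. For the measured compounds named here, no measured step involves isopropyl, so the recorded steps bear on it only indirectly, through what exchanges at this same aromatic carbon have done so far: the step of a number 17 percentage points lower from compound 1 to compound 3 (beyond the scatter) was modest, and the step of a number 7 percentage points higher from compound 2 to compound 3 (within the scatter) was within the scatter. Exchanges at this position have therefore moved the number by modest amounts at most, and the three compounds span a band whose lower end is compound 2 with 39% and whose upper end is compound 1 with 63%. Compound 4 is expected to fall within that band, and the step of a number 2 percentage points higher from compound 3 to compound 4 (within the scatter) is expected to stay within the scatter or close to it, with the direction uncertain. Compound 4 is estimated at 48%, with a range from 32% to 64%.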

Compound 4, a percentage reported as inhibition, in the whole organism at one dose (the size of the read-out at that dose, not a potency): 29%
Compound 4: the middle estimate sits 19 percentage points above what was measured; measured number below the stated range.
By their numbers in this assay, from the lowest: compounds 4, 2 and 3 (each within the scatter of the next, the first and the last beyond it); then compound 1.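

For the compounds shown here, at this aromatic carbon, para to a large group, the exchanges so far do not leave the number in this assay within a modest band: isopropyl in place of bromo gives a number 17 percentage points lower from compound 3 to compound 4 (beyond the scatter), and isopropyl in place of methoxy gives a number 34 percentage points lower from compound 1 to compound 4 (beyond the scatter), the first large step at this position. Compound 4 cannot be separated from the compound with the sulfur-bearing group, as the step is a number 10 percentage points lower from compound 2 to compound 4 (within the scatter), so two groups with no heteroatom in common give numbers within the scatter of each other, while methoxy stands apart from bromo, isopropyl and the sulfur-bearing group. No measurement at hand accounts for these steps.

The compounds shown leave open whether a smaller or unbranched carbon group such as methyl or ethyl at this carbon would stay close to compound 4, and whether a longer ether such as ethoxy or an amine such as dimethylamino would come close to compound 1. They also leave open whether these steps would hold at a dose other than the single one reported.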